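The source may hold more compounds than are shown below. What is called first, only, known or untested is meant among the compounds shown, and "the series" means these compounds.

Working notes on the series.

Of the compounds shown here, three have a number so far. Compound 1 `COc1ccc(C)cc1N1C(=O)CSC1c1cccc(C(=O)NCCCCc2ccccc2)c1` gives 300 nM in a functional assay on HOS-TE85 cells (Homo sapiens) for inhibition, read by CCK-8 assay, with a stated time of 72 h (on this read-out higher numbers stand for weaker inhibition and lower numbers for stronger inhibition), the highest of the three numbers. Compound 2 `COc1ccccc1N1C(=O)CSC1c1cc(C(=O)NCCCCc2ccccc2)cc(C2CC2)c1` gives 23.5 nM in this assay, and compound 3 `O=C(NCCCCc1ccccc1)c1cc(F)cc(C2SCC(=O)N2c2ccccn2)c1` gives 14.2 nM. Both of these sit well beyond the scatter from compound 1, so compound 1 is the weakest inhibitor of the three as the numbers stand. Among the compounds with values here, no two measured compounds differ in only one place, so no single step has been isolated yet.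

Compound 4 `O=C(NCCCCc1ccccc1)c1cccc(C2SCC(=O)N2c2ccc(C3CC3)cc2)c1` is the next one to be measured. It differs from compound 1 in one place:

4-cyclopropylphenyl in place of 2-methoxy-5-methylphenyl on an amide-type nitrogen in a ring

The replaced group leaves no hydrogen-bond acceptor in its place. What the other two compounds show is that the core of compound 1 tolerates other groups on the amide-type nitrogen in a ring with lower numbers, but neither of them carries 4-cyclopropylphenyl there, so the comparison is indirect. The expectation is a step downward, of moderate size, from compound 1 to compound 4 of a 3.0-fold lower number from compound 1 to compound 4 (0.48 log units; beyond the scatter) in this assay. Compound 4 is therefore estimated at 100 nM, within a range of 30 nM to 400 nM.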

Compound 4, half-maximal inhibitory concentration: 217 nM
Estimate against measurement, compound 4: 2.2-fold (0.34 log units) below, within the range that was stated.
By their numbers in this assay, from the lowest: compounds 3 and 2 (each within the scatter of the next); then compounds 4 and 1 (each within the scatter of the next).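

In this assay, within the data shown here, the exchange of 2-methoxy-5-methylphenyl for 4-cyclopropylphenyl on the amide-type nitrogen in a ring gives a 1.4-fold lower number from compound 1 to compound 4 (0.14 log units; within the scatter) and so provides the first single-place comparison, with the two compounds not separated at this position. The leaving group carries a hydrogen-bond acceptor and the entering group carries none, yet the pair stays within the scatter, so in this pair the loss of that acceptor and of the methoxy and methyl groups comes with no measurable shift, even though the heavy-atom count of the group is unchanged and a three-membered carbon ring enters. No measurement of any property or other supporting data bears on this result, so the pair gives no account of why the two groups read alike.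

Among these compounds, the single step changes the methoxy, the methyl and the cyclopropyl together, which leaves the separate contribution of each group unresolved. Also open, from the compounds shown here alone, is what this position gives with a group of another kind on the phenyl ring, such as a dimethylamino group, a carboxylic acid or a longer alkyl chain in place of the cyclopropyl.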